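The source may report more compounds than this note shows. Statements on the series, on what has been measured and on what is new or still open speak of the compounds shown alone.

Of the compounds shown here, three from one series have been tested in a functional assay on HCT-116 cells (Homo sapiens) for inhibition, read by MTT assay, with a stated time of 72 h, tested at 20 uM; a lower number here means less inhibition, a higher number more inhibition at the concentration tested (going by the name of the read-out). Compound 1, `c1cc(N2CCCCC2)nc(Nc2ccc(Oc3ncnc4sccc34)cc2)n1`, gives 66.3%. Compound 2, `CN(c1ccc(Oc2ncnc3ccsc23)cc1)c1nccc(N2CCCCC2)n1`, gives 66.2%. Compound 3, `CN(c1ccc(Oc2ncnc3sccc23)cc1)c1nccc(N2CCCC2)n1`, gives 42.2%, the lowest of the three numbers; its distance to compound 2 and its distance to compound 1 both lie beyond the usual scatter of this measurement. The fourth compound, compound 4, `CN(c1ccc(Oc2ncnc3sccc23)cc1)c1nccc(N2CCCCC2)n1`, has not yet been measured in this assay.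

Compound 4 differs from compound 3 in a single place: piperidin-1-yl in place of pyrrolidin-1-yl on an aromatic carbon. Within the data shown here, no pair of the measured compounds differs in exactly one place, so no measured step tells directly what such a swap does. What the numbers do show is that the two compounds carrying piperidin-1-yl, compound 1 and compound 2, both sit well above compound 3, which carries pyrrolidin-1-yl, although the three also differ elsewhere. On that thin basis, an upward step from compound 3 to compound 4 is expected, of a size beyond the scatter, expected as a number 20.8 percentage points higher from compound 3 to compound 4 (beyond the scatter) in this assay. The estimate for compound 4 in this assay is therefore 63%, with an expected range from 48% to 76%.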

Compound 4, a percentage reported as inhibition, at one concentration (the size of the read-out at that concentration, not a potency): 52.2%
For compound 4 the middle estimate is 10.8 percentage points above the measured one, within the range that was stated.
By their numbers in this assay, from the lowest: compounds 3 and 4 (each within the scatter of the next); then compounds 2 and 1 (each within the scatter of the next).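

Exchanging pyrrolidin-1-yl for piperidin-1-yl on this aromatic carbon, next to the ring nitrogen, gives a number 10 percentage points higher from compound 3 to compound 4 (within the scatter) in this assay, so this direct comparison cannot separate the two rings at this position. Two other single changes do give steps beyond the scatter, both modest: placing methyl instead of hydrogen on the nitrogen on an aromatic ring gives a number 14.1 percentage points lower from compound 1 to compound 4 (beyond the scatter), and exchanging the group on the oxygen for another of the same atomic makeup gives a number 14 percentage points lower from compound 2 to compound 4 (beyond the scatter). Within these pairs, then, the piperidin-1-yl to pyrrolidin-1-yl change is the only one that stays within the scatter, while the nitrogen substituent and the arrangement of the group on the oxygen each come with a measurable step.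

On these data alone, it remains open whether another cyclic amine on the same carbon, such as morpholin-4-yl or 4-methylpiperazin-1-yl, would move the number beyond the scatter, and whether ethyl on the nitrogen would behave as methyl does. Nothing in the available data accounts for the size of any of these steps.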